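The source may report more compounds than this note shows. Statements on the series, on what has been measured and on what is new or still open speak of the compounds shown alone.

Three compounds share one core and differ only in the group carried on a saturated chain carbon bound to a saturated ring carbon. Compound 1 `Cn1ncc(Cl)c1-c1cc(C(=O)N[C@@H]2CN[C@H](CC(=O)NC3CC3)C[C@H]2c2ccc(Cl)c(Cl)c2)oc1Cl` carries a cyclopropylcarbamoyl group there, and in an assay for inhibition of RAC-alpha serine/threonine-protein kinase (Homo sapiens), read by HTRF, with a stated time of 1 h (on this read-out higher numbers stand for weaker inhibition and lower numbers for stronger inhibition), compound 1 gives 3.95 nM. Compound 2 `C=CC[C@@H]1C[C@@H](c2ccc(Cl)c(Cl)c2)[C@H](NC(=O)c2cc(-c3c(Cl)cnn3C)c(Cl)o2)CN1` carries a vinyl group instead, and in this assay compound 2 gives 12.4 nM, which is a 3.1-fold higher number from compound 1 to compound 2 (0.50 log units; beyond the scatter). Compound 3 `Cn1ncc(Cl)c1-c1cc(C(=O)N[C@@H]2CN[C@H](CC(=O)NCC(O)CO)C[C@H]2c2ccc(Cl)c(Cl)c2)oc1Cl` carries a (2,3-dihydroxypropyl)carbamoyl group, and in this assay compound 3 gives 3.13 nM. That amounts to a 1.3-fold lower number from compound 1 to compound 3 (0.10 log units; within the scatter) and a 4.0-fold lower number from compound 2 to compound 3 (0.60 log units; beyond the scatter). Compound 3 thus has the lowest of the three numbers, but its gap to compound 1 lies within the scatter, so those two cannot be told apart; only compound 2 stands clearly higher.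

Compound 4 `Cn1ncc(Cl)c1-c1cc(C(=O)N[C@@H]2CN[C@H](CC(=O)NCCO)C[C@H]2c2ccc(Cl)c(Cl)c2)oc1Cl` shortens the chain on the amide-type nitrogen: hydrogen in place of hydroxymethyl on a saturated chain carbon bound to an oxygen on a saturated carbon and a saturated chain carbon. Within the data shown here, the one measured step that bears on this is the one from compound 1 to compound 3, where a change on the same amide-type nitrogen gave a 1.3-fold lower number from compound 1 to compound 3 (0.10 log units; within the scatter), a move within the scatter. Trimming a hydroxymethyl from that chain is therefore expected to matter little, an estimated 1.1-fold higher number from compound 3 to compound 4 (0.05 log units; within the scatter). In this assay compound 4 is expected to give 3.5 nM, within a range from 1.5 nM to 8 nM.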

Compound 4, half-maximal inhibitory concentration: 1.41 nM
Estimate against measurement, compound 4: 2.5-fold (0.39 log units) above; measured number outside the range, below it.
By their numbers in this assay, from the lowest: compound 4; then compounds 3 and 1 (each within the scatter of the next); then compound 2.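

In this assay, the group on the amide-type nitrogen turns out to matter: taking away one hydroxymethyl gives a change that can be read (a 2.2-fold lower number from compound 3 to compound 4 (0.35 log units; beyond the scatter)), whereas the earlier swap of cyclopropyl for 2,3-dihydroxypropyl on that nitrogen stayed within the scatter. The 2-hydroxyethyl group also separates clearly from cyclopropyl (a 2.8-fold lower number from compound 1 to compound 4 (0.45 log units; beyond the scatter)) and further still from the vinyl group (an 8.8-fold lower number from compound 2 to compound 4 (0.94 log units; beyond the scatter)), so compound 4 is the most potent of the four, with its steps to all the others beyond the scatter. Nothing available explains why removing this small piece lowers the number.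

As far as these compounds go, it remains open whether the hydroxyl of the 2-hydroxyethyl group is needed at all, and an ethyl or a 2-methoxyethyl group on the same nitrogen would speak to that. A 3-hydroxypropyl chain, a 2-aminoethyl group or a carboxymethyl group there would show whether the number keeps falling or rises again once the end of the chain is lengthened or its hydroxyl is replaced by an amine or a carboxylic acid.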